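The source may report more compounds than this note shows. Statements on the series, on what has been measured and on what is new or still open speak of the compounds shown alone.

Measured so far:
compound 1, `CCCCCCCC(=O)O[C@H]1[C@H](O)[C@H](n2ccc(N)nc2=O)O[C@@H]1CO`, gives 0.1 ug/mL in a functional assay on HeLa cells (Homo sapiens) for cytotoxicity, read by cell counting, with a stated time of 48 h; a lower number here means that less compound is needed, a higher number that more compound is needed for the effect;
compound 2, `CCCCCCCCCCCCCCCCCCCC(=O)O[C@H]1[C@H](O)[C@H](n2ccc(N)nc2=O)O[C@@H]1CO`, gives 0.1 ug/mL in this assay.

Compound 2 stands level with compound 1: the step of no change at the digits printed from compound 1 to compound 2 (within the scatter). Compound 3, `CCCCCCCCC(=O)O[C@H]1[C@H](O)[C@H](n2ccc(N)nc2=O)O[C@@H]1CO`, differs from compound 2 by hydrogen in place of undecyl on a saturated chain carbon, eight bonds along the chain from a carbonyl carbon. For the measured compounds named here, the one measured step, no change at the digits printed from compound 1 to compound 2 (within the scatter), adds a much larger group of the same kind and shows no change within the scatter, so removing part of it is expected to give no step beyond the scatter in this assay. The value expected for compound 3 is 0.1 ug/mL, with a range from 0.05 ug/mL to 0.2 ug/mL. This means an expected step of no change at the digits printed from compound 2 to compound 3 (within the scatter).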

Compound 3, concentration for half-maximal effect: 0.05 ug/mL
Beside the measured number, compound 3's estimate is 2.0-fold (0.30 log units) above it; the measured number falls inside the stated range.
By their numbers in this assay, from the lowest: compounds 3, 1 and 2 (each within the scatter of the next).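

In this assay, the long undecyl group can go, with hydrogen in its place eight bonds along the chain from a carbonyl carbon, and the result is a 2.0-fold lower number from compound 2 to compound 3 (0.30 log units; within the scatter) for this large change. The smallest change shown, methyl in place of hydrogen seven bonds along the chain from a carbonyl carbon, gives a 2.0-fold lower number from compound 1 to compound 3 (0.30 log units; within the scatter), so both the small and the large change in chain length stay within the scatter. Nothing available explains why these chains read alike.

Open, going by these compounds, is whether an amine or a carboxylic acid in place of the undecyl would hold this level. Much shorter chains also remain open.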